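The source may hold more compounds than are shown below. What is called first, only, known or untested is meant among the compounds shown, and "the series" means these compounds.

Compound 1 `C[S+]([O-])c1ccc(CNC(=O)c2ccc(C(C)(C)C)cc2)cc1` is one of three amides measured in an assay on HeLa cells with Bile acid receptor (Homo sapiens) as the target, read by a luciferase reporter, with a stated time of 24 h (on this read-out higher numbers stand for an effect only at larger amounts of compound and lower numbers for an effect already at smaller amounts), where compound 1 gives 1300 nM. Compound 2 `O=C(O)c1ccc(CNC(=O)c2ccc3ccccc3c2)cc1` gives 1360 nM in this assay, and compound 3 `CC(C)(C)c1ccc(C(=O)NCc2ccc(C(=O)O)cc2Cl)cc1` gives 7500 nM. Compound 1 thus shows the lowest of the three numbers, yet compound 2 lies within the usual scatter of it, and only compound 3 stands beyond that scatter at a higher number.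

Compound 4 `CC(C)(C)c1ccc(C(=O)NCc2ccc(-c3nnn[nH]3)cc2)cc1` has not been measured. It differs from compound 1 in one place: a group of 5 heavy atoms (1 carbon, 4 nitrogen; one five-membered aromatic ring with 4 hetero atoms) in place of a group of 3 heavy atoms (1 carbon, 1 oxygen, 1 sulfur; no ring), on an aromatic carbon. Within the data shown here, no measured pair in this set differs in a single place, so nothing recorded shows directly how such an exchange at this position moves the read-out. Because compound 1 with 1300 nM and compound 2 with 1360 nM sit so close despite differing in several places, the step from compound 1 to compound 4 is expected to be small, a 1.3-fold lower number from compound 1 to compound 4 (0.11 log units; within the scatter), likely within the scatter. Compound 4 is therefore expected to give 1000 nM, with a range from 300 nM to 4000 nM.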

Compound 4, half-maximal effective concentration: 120 nM
Compound 4: middle estimate off by 8.3-fold (0.92 log units), on the high side; measured number outside the range, below it.
By their numbers in this assay, from the lowest: compound 4; then compounds 1 and 2 (each within the scatter of the next); then compound 3.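

In this assay, among these compounds, replacing the group on the aromatic carbon of compound 1 with 1H-tetrazol-5-yl gives an 11-fold lower number from compound 1 to compound 4 (1.03 log units; beyond the scatter), the only step in this set that changes a single place. It shows that this position, para to a large group, is not indifferent to what it carries: with the rest of the structure unchanged, this one exchange moves the read-out well beyond the scatter. Nothing measured here explains the size of this step.

With only one exchange shown at this position, it remains open whether the step is particular to 1H-tetrazol-5-yl or would also appear with another group, such as a nitrile or an amine. As far as these compounds go, it is equally open whether the same exchange would have a similar effect with another group in place of the tert-butyl.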